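Swapping the aryl group on the sulfonyl sulfur

The source may hold more compounds than are shown below. What is called first, only, known or untested is meant among the compounds shown, and "the series" means these compounds.

Compound 1 `COc1ccc(C(=O)N(C)c2ccc3[nH]c(-c4n[nH]c5ccccc45)cc3n2)cc1`: 12900 nM
Compound 2 `CN(C(=O)c1ccco1)c1ccc2[nH]c(-c3n[nH]c4ccccc34)cc2n1`: 19400 nM
Compound 3 `CN(c1ccc2[nH]c(-c3n[nH]c4ccccc34)cc2n1)S(=O)(=O)c1ccc(Cl)cc1`: 8350 nM

All three values come from a functional assay on KB cells (Homo sapiens) for antiproliferative activity, read by MTT assay, with a stated time of 72 h; a higher number here means a weaker inhibitor, a lower number a stronger inhibitor. Among the compounds with values here, the standing of the only sulfonyl compound among them is told by two steps: a 1.5-fold lower number from compound 1 to compound 3 (0.19 log units; within the scatter), and a 2.3-fold lower number from compound 2 to compound 3 (0.37 log units; beyond the scatter).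

The next compound is compound 4 `CN(c1ccc2[nH]c(-c3n[nH]c4ccccc34)cc2n1)S(=O)(=O)c1cccc([N+](=O)[O-])c1`, which has 3-nitrophenyl in place of 4-chlorophenyl on a sulfonyl sulfur. Within the data shown here, no measured pair changes the group on a sulfonyl sulfur, so the evidence is indirect. The closest guide is a swap of the group on a carbonyl carbon, a 1.5-fold higher number from compound 1 to compound 2 (0.18 log units; within the scatter). The two steps above replace the whole group on the nitrogen, and they are no more than modest. With only these three values to go on, no step beyond the scatter is expected in this assay, in either direction.

The expected step is a 1.1-fold higher number from compound 3 to compound 4 (0.03 log units; within the scatter). For compound 4 the estimated value is 9000 nM, with an expected range from 3500 nM to 23000 nM.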

Compound 4, half-maximal inhibitory concentration: 5870 nM
For compound 4 the middle estimate is 1.5-fold (0.19 log units) above the measured one; the measured number falls inside the stated range.
By their numbers in this assay, from the lowest: compounds 4, 3, 1 and 2 (each within the scatter of the next, the first and the last beyond it).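

Within the data shown here, this is the first pair that differs only in the aryl group on a sulfonyl sulfur, and in this assay it gives a 1.4-fold lower number from compound 3 to compound 4 (0.15 log units; within the scatter). 4-Chlorophenyl can therefore be replaced by 3-nitrophenyl, a group with more heavy atoms and with hydrogen-bond acceptors where the group it replaces has none, and the two numbers still lie within the scatter of each other. Nothing shown here bears on the reason for this result.

Going by these compounds, what an amine or a carboxylic acid on that phenyl ring, or a plain methyl on the sulfonyl sulfur, would do to the number remains open. Also open, on these data alone, is how 3-nitrophenyl would read on a carbonyl carbon, in place of the 4-methoxyphenyl and furan-2-yl groups found there.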